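Swapping a Bromine for a Pyrrolidine Amide

The compounds below may be only part of what the source reports. "The series", "measured", "known", "first", "only" and "open" are said of these compounds alone.

Compound 1 `O=C1N/C(=C\c2ccc(O)cc2)C(=O)N1c1ccc(Br)cc1` carries a bromo group on its outer ring; in a functional assay on NCI-H292 cells (Homo sapiens) for antiproliferative activity (on this read-out higher numbers stand for weaker inhibition and lower numbers for stronger inhibition), compound 1 gives 69900 nM, the only full number shown. Compound 2 `O=C1N/C(=C\c2ccc(O)cc2)C(=O)N1c1cccc(Br)c1` reaches only a limit of this assay, > 200000 nM. The step of an at least 2.8-fold higher number from compound 1 to compound 2 (0.45 log units; beyond the scatter) rests on (the limit of > 200000 nM in this assay, at which 1 of the 2 values shown sits). Compound 3 `O=C(c1ccc(N2C(=O)N/C(=C\c3ccc(O)cc3)C2=O)cc1)N1CCCC1` differs from compound 1 by (pyrrolidin-1-yl)carbonyl in place of bromo on an aromatic carbon. Among the measured compounds shown here, the one measured step moved the bromo rather than replacing it, so it bears only loosely here, and no step beyond the scatter is expected. For compound 3 the expected value is 70000 nM, between 15000 nM and 200000 nM, a step of a 1.0-fold higher number from compound 1 to compound 3 (0.00 log units; within the scatter).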

Compound 3, half-maximal inhibitory concentration: > 200000 nM
Compound 3 gave a limit, no number; the forecaster's own chance of this, stated with the estimate: 30%; middle value at least 2.8-fold (0.45 log units) away from the limit.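

Replacing the bromo group, rather than moving it as in compound 2, also weakens the effect: in this assay the change gives an at least 2.8-fold higher number from compound 1 to compound 3 (0.45 log units; beyond the scatter). On this aromatic carbon, then, the (pyrrolidin-1-yl)carbonyl group does not keep the activity that the bromo group gives. Compound 3 sits at a limit, not at a number, so the true size of this step stays unknown: the limit of > 200000 nM in this assay, at which 2 of the 3 values shown sit.

On these data alone, whether a simple amine or a carboxylic acid on that same carbon would hold the activity of compound 1 remains open. So does whether any group there would give stronger inhibition than bromo.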